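The compounds below may be only part of what the source reports. "The series", "measured", "known", "first", "only" and "open" are said of these compounds alone.

Among the compounds with values here, in a functional assay on MCF7 cells (Homo sapiens) for antiproliferative activity, read by MTT assay, with a stated time of 48 h (a lower number here means a stronger inhibitor, a higher number a weaker inhibitor), compound 1 `COc1ccc(-c2nnc(NC(=O)/C=C/c3ccc(C)cc3)s2)cc1` gives 0.31 ug/mL, the lowest of the two numbers so far, while compound 2 `Cc1ccc(/C=C/C(=O)Nc2nnc(-c3ccccc3)s2)cc1` gives 1.23 ug/mL. Compound 3 `COc1ccc(/C=C/C(=O)Nc2nnc(-c3ccc(OC)cc3)s2)cc1` has not been measured. It differs from compound 1 by methoxy in place of methyl on an aromatic carbon, with methoxy in place of methyl on an aromatic carbon. Within the data shown here, the only measured step, a 4.0-fold higher number from compound 1 to compound 2 (0.60 log units; beyond the scatter), is modest and lies beyond the scatter, but it concerns a different place in the molecule, so it offers only indirect guidance. The expected size of the change is small, with the estimated 1.1-fold higher number from compound 1 to compound 3 (0.05 log units; within the scatter) staying within the scatter in this assay. For compound 3 the estimated value is 0.35 ug/mL, with an expected range of 0.12 ug/mL to 1 ug/mL.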

Compound 3, half-maximal inhibitory concentration: 0.28 ug/mL
For compound 3 the middle estimate is 1.3-fold (0.10 log units) above the measured one; the range from low to high includes it.
By their numbers in this assay, from the lowest: compounds 3 and 1 (each within the scatter of the next); then compound 2.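

Changing 4-methylphenyl to 4-methoxyphenyl gives a 1.1-fold lower number from compound 1 to compound 3 (0.04 log units; within the scatter) in this assay and so shows that this position accepts methoxy as readily as methyl, with the two numbers indistinguishable. The earlier step, hydrogen in place of methoxy, concerned a different place in the molecule and lay beyond the scatter, whereas this swap of methyl for methoxy does not. Nothing shown here explains this result.

On these data alone, whether an amine, a carboxylic acid or a longer chain at this position would also leave the number within the scatter remains open.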